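Notes on compound 4: amino in place of methoxy

The source may report more compounds than this note shows. Statements on the series, on what has been measured and on what is new or still open speak of the compounds shown alone.

Measured so far, in a functional assay on DU-145 cells (Homo sapiens) for cytotoxicity, read by MTT assay, with a stated time of 72 h; on this read-out higher numbers stand for weaker inhibition and lower numbers for stronger inhibition:
compound 1, `COc1ccc(C(=O)c2cc(OC)c(OC)c(OC)c2)cc1NC(=O)/C=C/c1ccc(C(F)(F)F)cc1`, gives 4300 nM
compound 2, `COc1cc(/C=C/C(=O)Nc2cc(C(=O)c3cc(OC)c(OC)c(OC)c3)ccc2OC)ccc1F`, gives 12100 nM
compound 3, `COc1ccc(/C=C/C(=O)Nc2cc(C(=O)c3cc(OC)c(OC)c(OC)c3)cc(OC)c2OC)cc1OC`, gives 7800 nM

Compound 3 stands second highest of the three numbers. Its nearest neighbour is compound 2 and its furthest is compound 1, and both gaps lie within the usual scatter, so compound 3 cannot be set apart from either. Going by the values given here, the only single-point step among the measured compounds is a 2.8-fold higher number from compound 1 to compound 2 (0.45 log units; beyond the scatter), which swaps the aryl group at the far end of the double-bonded chain. Compound 4, `COc1ccc(/C=C/C(=O)Nc2cc(C(=O)c3cc(OC)c(OC)c(OC)c3)cc(OC)c2OC)cc1N`, differs from compound 3 by amino in place of methoxy on an aromatic carbon. Among the compounds with values here, this change sits on the same aryl ring that the step from compound 1 to compound 2 altered, but amino in place of methoxy has no measured precedent, and the one step seen on that ring was only modest. The expected step in this assay is therefore a 1.4-fold lower number from compound 3 to compound 4 (0.15 log units; within the scatter), most likely within the scatter and without a firm direction. Compound 4 is estimated at 5500 nM, with a range from 1800 nM to 17000 nM.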

Compound 4, half-maximal inhibitory concentration: 12700 nM
Estimate against measurement, compound 4: 2.3-fold (0.36 log units) below; the measured number falls inside the stated range.
By their numbers in this assay, from the lowest: compounds 1, 3, 2 and 4 (each within the scatter of the next, the first and the last beyond it).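

In this assay, amino in place of methoxy, on an aromatic carbon ortho to a methoxy group, gives a 1.6-fold higher number from compound 3 to compound 4 (0.21 log units; within the scatter), so compound 3 and compound 4 cannot be told apart. The 3,4-dimethoxyphenyl and 3-amino-4-methoxyphenyl ends therefore read alike here, even though a hydrogen-bond donor enters with the amino group. Going by these compounds alone, this is the first single-point reading for this position, as the earlier step replaced the whole aryl group. Nothing available bears on why the two compounds read alike.

Other groups at this position, such as a hydroxyl, a dimethylamino or an acetamide, remain open. So does whether the same swap reads alike on the core shared by compound 1 and compound 2, which lacks one methoxy of compound 3.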